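A few compounds are considered here, and "the series" means these few. Any claim that something is new, unique, unknown or untested is made for them only; others in the source may bear on it.

Working notes on the series in a functional assay on NCI-H1975 cells (Homo sapiens) for antiproliferative activity, read by CCK-8 assay, with a stated time of 72 h; on this read-out lower numbers stand for stronger inhibition of growth and higher numbers for weaker inhibition of growth. Compound 1 (`CCC1C(=O)N(C)c2cnc(-n3ccc4cc(F)ccc43)nc2N1c1ccn(C)n1`) gives 28600 nM, and compound 2 (`CCCCNC(=O)c1ccc2c(ccn2-c2ncc3c(n2)N(c2ccn(C)n2)C(CC)C(=O)N3C)c1`) gives 12000 nM. That is a 2.4-fold lower number from compound 1 to compound 2 (0.38 log units; beyond the scatter), with butylcarbamoyl in place of fluoro on an aromatic carbon. Compound 3 (`CCNC(=O)c1ccc2c(ccn2-c2ncc3c(n2)N(c2ccn(C)n2)C(CC)C(=O)N3C)c1`) has no number to stand on: it is recorded only as "not active" (no number reported).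

Compound 4 (`CCC1C(=O)N(C)c2cnc(-n3ccc4cc(C(=O)NC5CCCC5)ccc43)nc2N1c1ccn(C)n1`) differs from compound 3 by cyclopentyl in place of ethyl on an amide-type nitrogen, which is cyclopentyl in place of ethyl on an amide-type nitrogen. Within the data shown here, no measured step covers this exchange, and without a number for compound 3 its size cannot be stated. Among the measured compounds shown here, the one measured step, from compound 1 to compound 2, is modest and concerns a different change, so it bears only indirectly. A measurable value in the weak range is expected for compound 4, which would be a move toward stronger inhibition of growth than compound 3 shows, with compound 2 at 12000 nM as the nearest anchor. A result with no number also remains possible. Compound 4 is estimated at 12000 nM, with an expected range of 4000 nM to 35000 nM.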

Compound 4, concentration for 50% growth inhibition: "not active" (no number reported)
Nothing numeric was reported for compound 4; no gap can be computed for the estimate.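

In this assay compound 3 and compound 4 both lack a number, so no new step can be read from them, and nothing measured here accounts for this result. The compounds shown leave open how ethylcarbamoyl and cyclopentylcarbamoyl would rank against each other or against the butylcarbamoyl of compound 2.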